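Cyano in Place of Chloro on the Benzyloxy Ring

This account rests on a few compounds, and the source may have more. Where it says the series, first, only, none or still open, it means among the compounds named here.

Compound 3 `FC(F)(F)c1ccc(CN2CCN(Cc3cc(-c4ccc(OCc5ccc(Cl)cc5)cc4)on3)CC2)cc1` shows the highest of the three numbers measured in a functional assay on MCF7 cells (Homo sapiens) for antiproliferative activity, read by sulforhodamine B assay, with a stated time of 72 h (a lower number here means a stronger inhibitor, a higher number a weaker inhibitor), where compound 3 gives 6700 nM. Compound 1 `Cc1ccccc1COc1ccc(-c2cc(CN3CCN(Cc4ccc(C(F)(F)F)cc4)CC3)no2)cc1` gives 3700 nM and compound 2 `Cc1cccc(COc2ccc(-c3cc(CN4CCN(Cc5ccc(C(F)(F)F)cc5)CC4)no3)cc2)c1` gives 4000 nM; the steps of a 1.8-fold higher number from compound 1 to compound 3 (0.26 log units; within the scatter) and a 1.7-fold higher number from compound 2 to compound 3 (0.22 log units; within the scatter) both stay within the scatter, as does a 1.1-fold higher number from compound 1 to compound 2 (0.03 log units; within the scatter). Compound 4 `N#Cc1ccc(COc2ccc(-c3cc(CN4CCN(Cc5ccc(C(F)(F)F)cc5)CC4)no3)cc2)cc1` differs from compound 3 by cyano in place of chloro on an aromatic carbon. Among the compounds with values here, the steps that bear on this each exchanged the ring on the saturated chain carbon bound to an oxygen on an aromatic ring and moved the number only within the scatter, so no step beyond the scatter is expected in this assay. The step expected is a 1.1-fold lower number from compound 3 to compound 4 (0.05 log units; within the scatter). Compound 4 is therefore estimated at 6000 nM, between 2500 nM and 15000 nM.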

Compound 4, half-maximal inhibitory concentration: 100 nM
Compound 4: middle estimate off by 60-fold (1.78 log units), on the high side; measured number below the stated range.
By their numbers in this assay, from the lowest: compound 4; then compounds 1, 2 and 3 (each within the scatter of the next).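

In this assay, within the data shown here, exchanging the ring on the saturated chain carbon had so far moved the number only within the scatter, yet cyano in place of chloro gives a 67-fold lower number from compound 3 to compound 4 (1.83 log units; beyond the scatter) and shows that this position can respond strongly. The 4-cyanophenyl compound also stands clear of both methylphenyl compounds, with a 40-fold lower number from compound 2 to compound 4 (1.60 log units; beyond the scatter) and a 37-fold lower number from compound 1 to compound 4 (1.57 log units; beyond the scatter). No measurement shown accounts for this drop. The compounds shown leave open whether a carboxylic acid or a primary amide on that aromatic carbon would give a similarly low number.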